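The compounds below may be only part of what the source reports. "The series", "measured", "known", "first", "only" and "open" are said of these compounds alone.

Measured so far:
compound 1, `C[C@@H](Sc1nc2c(cnn2C)c(=O)n1-c1ccccc1)c1ccccc1`, 40 nM
compound 2, `CC(Sc1nc2c(cnn2C)c(=O)n1-c1ccccc1)c1ccccn1`, 63 nM
compound 3, `CCC(Sc1nc2c(cnn2C)c(=O)n1-c1ccccc1)c1ccccc1`, 179 nM

In an assay on isolated protein for inhibition of retinal dehydrogenase 2 (Homo sapiens) (a lower number here means a stronger inhibitor, a higher number a weaker inhibitor), compound 3 gives the highest number of the three. Both steps onto it, a 4.5-fold higher number from compound 1 to compound 3 (0.65 log units; beyond the scatter) and a 2.8-fold higher number from compound 2 to compound 3 (0.45 log units; beyond the scatter), lie beyond the scatter, so compound 3 is the weakest inhibitor of this small set. Compounds 1 and 2 lie within the scatter of each other, a 1.6-fold higher number from compound 1 to compound 2 (0.20 log units; within the scatter).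

Compound 4, `CC(Sc1nc2c(cnn2C)c(=O)n1-c1ccccc1)c1cccc(F)c1`, differs from compound 3 by 1-(3-fluorophenyl)ethyl in place of 1-phenylpropyl on a sulfur. Two things change at once. The 1-phenylpropyl group of compound 3 gives way to a 1-arylethyl group, which is the pattern of compounds 1 and 2; the step that bears on this is a 4.5-fold higher number from compound 1 to compound 3 (0.65 log units; beyond the scatter), which compound 4 would undo. Within the data shown here, the fluorine on the ring is untested in the set; no measured step speaks to it. The expectation is therefore a modest fall in this assay, roughly the reverse of the step from compound 1 to compound 3, with the fluorine left as an open uncertainty. The estimated step is a 3.0-fold lower number from compound 3 to compound 4 (0.47 log units; beyond the scatter). Compound 4 is expected at 60 nM, range 25 nM to 150 nM.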

Compound 4, half-maximal inhibitory concentration: 110 nM
For compound 4 the middle estimate is 1.8-fold (0.26 log units) below the measured one; the range from low to high includes it.
By their numbers in this assay, from the lowest: compounds 1, 2, 4 and 3 (each within the scatter of the next, the first and the last beyond it).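

In this assay, the fluorine on the ring of the 1-phenylethyl group gives a 2.8-fold higher number from compound 1 to compound 4 (0.44 log units; beyond the scatter), the first sign that this position on the sulfur responds to a substituent on the aryl ring. Compound 4 cannot be separated from either neighbouring compound, with a 1.6-fold lower number from compound 3 to compound 4 (0.21 log units; within the scatter) and a 1.7-fold higher number from compound 2 to compound 4 (0.24 log units; within the scatter) both inside the scatter, so 1-(3-fluorophenyl)ethyl stands apart only from 1-phenylethyl. No supporting data bear on why these steps take the sizes they do.

Open, from the compounds shown here alone, is how a methoxy group or a carboxylic acid on the ring, or an amine on the chain, would read at this sulfur. Going by these compounds, compound 1 is drawn with a defined configuration at the carbon on the sulfur and compound 4 without one, so how much of their gap belongs to the fluorine also stays open.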